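The source may report more compounds than this note shows. Statements on the series, on what has been measured and on what is new or still open speak of the compounds shown alone.

Compound 1 `CSc1cc(CSc2nc(-c3ccc(F)cc3)c(-c3ccncc3)[nH]2)ccc1O` and compound 2 `C[S+]([O-])c1cc(CSc2nc(-c3ccc(F)cc3)c(-c3ccncc3)[nH]2)ccc1O` share a core. In a functional assay (Homo sapiens) for inhibition (on this read-out lower numbers stand for stronger inhibition and higher numbers for weaker inhibition), compound 1 gives 280 nM and compound 2 gives 2300 nM, so compound 2 holds the higher of the two numbers and is the weaker inhibitor. Compound 3 `CSc1ccc(O)c(CSc2nc(-c3ccc(F)cc3)c(-c3ccncc3)[nH]2)c1` differs from compound 2 as follows: a group of 9 heavy atoms (7 carbon, 1 oxygen, 1 sulfur; one six-membered aromatic ring of carbon only) in place of a group of 10 heavy atoms (7 carbon, 2 oxygen, 1 sulfur; one six-membered aromatic ring of carbon only), on a saturated chain carbon bound to a sulfur. The entering 2-hydroxy-5-(methylsulfanyl)phenyl group has the methylsulfanyl of compound 1 in place of the oxygen-bearing sulfur group of compound 2, but it is not the ring of compound 1. Going by the values given here, only one measured step bears on this change, an 8.2-fold higher number from compound 1 to compound 2 (0.91 log units; beyond the scatter). Compound 3 is therefore expected to recover part of that modest step, giving a lower number than compound 2, though no measurement covers the altered ring. The expected size is a 3.3-fold lower number from compound 2 to compound 3 (0.52 log units; beyond the scatter). For compound 3 the estimated value is 700 nM, with an expected range from 200 nM to 2500 nM.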

Compound 3, half-maximal inhibitory concentration: 740 nM
For compound 3 the middle estimate is 1.1-fold (0.02 log units) below the measured one; the measured number falls inside the stated range.
By their numbers in this assay, from the lowest: compound 1; then compound 3; then compound 2.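

In this assay, the 2-hydroxy-5-(methylsulfanyl)phenyl group in place of 4-hydroxy-3-(methylsulfanyl)phenyl gives a 2.6-fold higher number from compound 1 to compound 3 (0.42 log units; beyond the scatter), which shows that the arrangement of the hydroxy and methylsulfanyl groups on the ring matters in itself, something compound 1 and compound 2 alone could not show. The change also gives a 3.1-fold lower number from compound 2 to compound 3 (0.49 log units; beyond the scatter), but this step alters both the sulfur group and its arrangement on the ring, so it cannot separate the two. Nothing measured here accounts for either step.

The compounds shown leave open how the oxygen-bearing sulfur group would fare on the ring of compound 3, and whether the hydroxy group is needed at all. They also do not tell how an ethylsulfanyl group, an amine or a carboxylic acid would compare in place of the methylsulfanyl group.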